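Trifluoromethoxy for fluoro in a urea series: cytotoxicity

The source may hold more compounds than are shown below. What is called first, only, known or untested is meant among the compounds shown, and "the series" means these compounds.

Measured compounds:
compound 1, `Cc1cc(NC(=O)Nc2ccccc2F)c2ccccc2n1`: > 25000 nM
compound 2, `Cc1cc(NC(=O)Nc2ccc(F)cc2)c2ccccc2n1`: > 25000 nM
compound 3, `Cc1cc(NC(=O)Nc2cccnc2)c2ccccc2n1`: > 25000 nM

Three ureas that share one core were tested in an ADME assay on HepG2 cells (Homo sapiens) for cytotoxicity, with a stated time of 72 h; a higher number here means that more compound is needed for the effect, a lower number that less compound is needed. In this assay compound 1 gives > 25000 nM, which is a limit of the assay rather than a measured number. In this assay compound 2 likewise gives > 25000 nM, again a limit. In this assay compound 3 gives > 25000 nM, also a limit. Compound 2 therefore stands only at a limit, and the two further values shown are limits as well: the limit of > 25000 nM in this assay, at which 3 of the 3 values shown sit.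

The steps between the measured compounds are a step that the two limits leave unreadable from compound 1 to compound 2, a step that the two limits leave unreadable from compound 1 to compound 3 and a step that the two limits leave unreadable from compound 2 to compound 3. None of them has a readable size, so they set no direction for any new change on this ring.

Compound 4, `Cc1cc(NC(=O)Nc2ccc(OC(F)(F)F)cc2)c2ccccc2n1`, differs from compound 2 in one place: trifluoromethoxy in place of fluoro on an aromatic carbon.

Within the data shown here, compound 4 is expected to show a step that the limit leaves unreadable from compound 2 to compound 4, because every value so far sits at the limit of > 25000 nM in this assay, at which 3 of the 3 values shown sit, and no step of readable size is available to predict otherwise. Compound 4 is estimated at 40000 nM, in a range from 15000 nM to 100000 nM, and most likely this assay would again report only a limit.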

Compound 4, half-maximal effective concentration: 15000 nM
Estimate against measurement, compound 4: 2.7-fold (0.43 log units) above; measured number inside the range.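

Among these compounds, compound 4 is the first compound with a value that can be read as a number in this assay: compound 4 gives 15000 nM. The change gives an at least 1.6-fold lower number from compound 2 to compound 4 (0.22 log units; that floor lies within the scatter), so the true gap could be larger, but what can be stated so far does not clear the usual scatter and shows only that trifluoromethoxy at this place, para to a large group, does not leave the result at the limit. The steps among the earlier compounds still cannot be read, and those compounds gave no such sign of a readable effect, since each of them stops at the same limit: the limit of > 25000 nM in this assay, at which 3 of the 4 values shown sit.

The compounds shown leave open whether a methoxy or a trifluoromethyl group at this place would also give a readable number, and what trifluoromethoxy would do in place of the fluoro of compound 1. They also leave open how far the true value of compound 2 lies beyond its limit, and that distance sets the real size of this step.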